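Side-chain terminus: hydroxy against pyrrolidin-1-yl

The compounds below may be only part of what the source reports. "The series", "measured", "known", "first", "only" and "open" are said of these compounds alone.

Measured in an assay for inhibition of RAC-alpha serine/threonine-protein kinase (Homo sapiens), read by HTRF, with a stated time of 1 h; a higher number here means a weaker inhibitor, a lower number a stronger inhibitor:
compound 1 `Cn1ncc(Cl)c1-c1cc(C(=O)N[C@@H]2CN[C@H](CCN3CCC(O)CC3)C[C@H]2c2ccc(Cl)c(Cl)c2)oc1Cl` gives 5.99 nM
compound 2 `Cn1ncc(Cl)c1-c1cc(C(=O)N[C@@H]2CN[C@H](CCO)C[C@H]2c2ccc(Cl)c(Cl)c2)oc1Cl` gives 2.74 nM

Among the measured compounds shown here, compound 2 holds the lower of the two numbers; the only step so far is a 2.2-fold lower number from compound 1 to compound 2 (0.34 log units; beyond the scatter), a modest change that accompanied hydroxy taking the place of 4-hydroxypiperidin-1-yl.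

Compound 3 `Cn1ncc(Cl)c1-c1cc(C(=O)N[C@@H]2CN[C@H](CCN3CCCC3)C[C@H]2c2ccc(Cl)c(Cl)c2)oc1Cl` differs from compound 2 by pyrrolidin-1-yl in place of hydroxy on a saturated chain carbon, two bonds along the chain from a saturated ring carbon. For the measured compounds named here, this reverses the direction of the one measured step, putting a ring nitrogen back at that chain position, so in this assay a modest move upward is expected, a 1.6-fold higher number from compound 2 to compound 3 (0.22 log units; within the scatter). Compound 3 is therefore estimated at 4.5 nM, with a range of 2 nM to 10 nM.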

Compound 3, half-maximal inhibitory concentration: 6.41 nM
Compound 3: middle estimate off by 1.4-fold (0.15 log units), on the low side; the measured number falls inside the stated range.
By their numbers in this assay, from the lowest: compound 2; then compounds 1 and 3 (each within the scatter of the next).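

Replacing hydroxy with pyrrolidin-1-yl on the 2-hydroxyethyl side chain gives a 2.3-fold higher number from compound 2 to compound 3 (0.37 log units; beyond the scatter), a step of similar size to the one seen with 4-hydroxypiperidin-1-yl. The two ring-bearing termini are not separated, with a 1.1-fold higher number from compound 1 to compound 3 (0.03 log units; within the scatter), so compound 2 stands apart from both compound 1 and compound 3. No supporting data explain this difference.

Still open, on these data alone, is whether an open-chain dimethylamino terminus would track with these rings or with hydroxy. A carboxylic acid at this position, or a longer chain carrying hydroxy, also remains to be placed.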